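The source may hold more compounds than are shown below. What is called first, only, known or untested is meant among the compounds shown, and "the series" means these compounds.

Measured in an ADME assay on the whole organism (Mus musculus, strain CD-1) for pharmacokinetics, at a dose of 10 mg/kg by the oral route; a higher number here means that a larger share of the oral dose reaches the circulation, a lower number that a smaller share of the oral dose reaches the circulation:
- compound 1 `CCOc1cc([C@](O)(CCN(C)C)[C@H](c2cccc(C)c2)c2cc3cc(Br)ccc3nc2OC)cc(OC)n1`: 65%
- compound 2 `CCOc1cc([C@](O)(CCN(C)C)[C@@H](c2cc3cc(Br)ccc3nc2OC)c2ccnc(OC)c2OC)cc(OC)n1`: 70%
- compound 3 `CCCOc1cc([C@](O)(CCN(C)C)[C@@H](c2cc3cc(Br)ccc3nc2OC)c2ccnc(OC)c2OC)cc(OC)n1`: 50%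

Compound 2 stands level with compound 1 at the top of these numbers (a number 5 percentage points higher from compound 1 to compound 2 (within the scatter)), and clear of compound 3. Compound 4 `CCOc1cc([C@](O)(CCN(C)C)[C@@H](c2cc3cc(Br)ccc3nc2OC)c2ccnc(OC)c2OC)cc(OC(C)C)n1` differs from compound 2 by isopropyl in place of methyl on an oxygen on an aromatic ring. The nearest measured change also adds carbon to a group on such an oxygen, with methyl in place of hydrogen on a saturated chain carbon: a number 20 percentage points lower from compound 2 to compound 3 (beyond the scatter). The change at the 3-methylphenyl group lies elsewhere and offers no guide. This single precedent suggests a modest fall. The expected step is a number 18 percentage points lower from compound 2 to compound 4 (beyond the scatter). Compound 4 is estimated at 52%, with an expected range of 32% to 70%.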

Compound 4, oral bioavailability: 58%
Compound 4: the middle estimate sits 6 percentage points below what was measured, and the stated range covers the measured number.
By their numbers in this assay, from the lowest: compounds 3, 4, 1 and 2 (each within the scatter of the next, the first and the last beyond it).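

In this assay, methoxy to isopropoxy on this oxygen gives a number 12 percentage points lower from compound 2 to compound 4 (beyond the scatter), so the group here is not neutral for the oral read-out. The earlier compounds shown here all carried the methoxy and so said nothing about this position. Nothing measured here bears on the reason for this step. The compounds shown leave open whether a longer straight chain on this oxygen would behave like the isopropyl, and whether a ring-bearing group or an amine at the end of a chain there would do the same.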